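The compounds below may be only part of what the source reports. "The series", "measured", "known", "first", "only" and "open" are said of these compounds alone.

Compound 1 `CC(=O)Nc1ccc2ncc(-c3cnn(C)c3)cc2n1` and compound 2 `Cn1cc(-c2cnc3ccc(NC(=O)C4CC4)nc3c2)cn1` share one core; compound 3 `CC(=O)Nc1nccc2ncc(-c3cnn(C)c3)cc12` is built from the same atoms as compound 1 joined differently, and the difference between the two cores is not broken down here. In a functional assay on HeLa cells (Homo sapiens) for antiproliferative activity, read by MTT assay, with a stated time of 48 h (on this read-out lower numbers stand for stronger inhibition and higher numbers for weaker inhibition), compound 1 reaches only a limit, > 50000 nM. Compound 2 likewise gives only a limit in this assay, > 50000 nM. Compound 3 also stops at a limit in this assay, > 50000 nM. The change from compound 1 to compound 2, (cyclopropyl in place of methyl on a carbonyl carbon), gives a step that the two limits leave unreadable from compound 1 to compound 2, since (the limit of > 50000 nM in this assay, at which 3 of the 3 values shown sit). Compound 4 `Cn1cc(-c2cnc3ccnc(NC(=O)C4CC4)c3c2)cn1` carries the same change on the core of compound 3, (cyclopropyl in place of methyl on a carbonyl carbon). The step that the limit leaves unreadable from compound 3 to compound 4 is expected to stay flat, resting on compound 3 and on (the limit of > 50000 nM in this assay, at which 3 of the 3 values shown sit). Compound 4 is estimated at 80000 nM in this assay, most probably again reported only as a limit.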

Compound 4, half-maximal inhibitory concentration: > 50000 nM
Compound 4 ended at the assay's limit; the forecaster's own chance of this, stated with the estimate: 90%; the middle value lies beyond the limit too.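

Compound 3 and compound 4 both stop at a limit in this assay, so no step between them can be read: the limit of > 50000 nM in this assay, at which 4 of the 4 values shown sit.

On these data alone, whether cyclopropyl in place of methyl on a carbonyl carbon changes activity on either core, and how the two cores compare in this assay, stays open.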